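The source may report more compounds than this note shows. Statements on the series, on what has been measured and on what is new or still open speak of the compounds shown alone.

Of the compounds shown here, two built on a shared core have been tested in an in vitro assay on U2OS cells for agonist activity at neurotensin receptor type 2 (Homo sapiens), read by reporter gene assay and beta-arrestin recruitment; on this read-out higher numbers stand for an effect only at larger amounts of compound and lower numbers for an effect already at smaller amounts. Compound 1 `COc1cc2nc(C3CCCC3)nc(N3CCN(c4ccccc4OC)CC3)c2cc1OC` reaches only the limit of > 80000 nM in this assay, so no number is known for it. Compound 2 `CCOc1ccccc1N1CCN(c2nc(C3CC3)nc3cc(OC)c(OC)cc23)CC1` likewise reaches only the limit of > 80000 nM. Compound 2 thus stands where both values shown stand, at the limit of > 80000 nM in this assay, at which 2 of the 2 values shown sit, and nothing separates it from compound 1 on the numbers.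

Compound 3 `COc1cc2nc(C3CC3)nc(N3CCNCC3)c2cc1OC` differs from compound 2 by hydrogen in place of 2-ethoxyphenyl on an amine nitrogen in a ring. For the measured compounds named here, no measured step between two compounds is available to gauge what such a change does here. The step from compound 2 to compound 3 is expected to be none beyond the scatter, with a step that the limit leaves unreadable from compound 2 to compound 3, since the starting point is already a limit. Compound 3 is therefore estimated at about 100000 nM, with a range from 20000 nM to 500000 nM, and most likely the assay will again report only a limit. The measurement will show whether this holds.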

Compound 3, half-maximal effective concentration: > 80000 nM
Compound 3 was reported as a limit (the forecaster's own chance of this, stated with the estimate: 85%); the middle value is on the limit's open side.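

In this assay compound 3 gives > 80000 nM, which is a limit and not a number. Compound 2 also stands at a limit, so the step between compound 2 and compound 3 cannot be read. All the values shown sit together: the limit of > 80000 nM in this assay, at which 3 of the 3 values shown sit.

The compounds shown leave open whether 2-ethoxyphenyl on the ring nitrogen matters at all for activity in this assay.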